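The source may report more compounds than this note shows. Statements on the series, on what has been measured and on what is new or still open speak of the compounds shown alone.

Compound 1 `Nc1ccccc1NC(=O)c1ccc(CSC(=S)N2CCN(c3ccc(Cl)cc3)CC2)cc1` gives 17.2% in a functional assay on MGC-803 cells (Homo sapiens) for antiproliferative activity, read by CCK-8 assay, with a stated time of 72 h, tested at 8 uM; on this read-out lower numbers stand for a weaker effect and higher numbers for a stronger effect at the one concentration tested.
Compound 2 `Nc1ccccc1NC(=O)c1ccc(CSC(=S)N2CCN(c3ccc(F)cc3)CC2)cc1` gives 48.7% in this assay.
Compound 3 `CN1CCN(C(=S)SCc2ccc(C(=O)Nc3ccccc3N)cc2)CC1` gives 84.4% in this assay.

Compound 3 stands highest of the three numbers, with compound 2 nearest and compound 1 furthest, both gaps beyond the scatter. Compound 4 `Nc1ccccc1NC(=O)c1ccc(CSC(=S)N2CCN(C3CCCCC3)CC2)cc1` differs from compound 3 in one place: cyclohexyl in place of methyl on an amine nitrogen in a ring. Among the compounds with values here, no measured step replaces methyl by cyclohexyl on that ring nitrogen. Two steps do alter the group on that nitrogen: a number 67.2 percentage points higher from compound 1 to compound 3 (beyond the scatter) and a number 35.7 percentage points higher from compound 2 to compound 3 (beyond the scatter), both large rises when methyl replaces an aryl group. Whether cyclohexyl falls with methyl or with the aryl groups is not shown. A fall beyond the scatter is therefore expected, a number 29.4 percentage points lower from compound 3 to compound 4 (beyond the scatter), smaller than those two steps. Compound 4 is expected to give 55%, between 30% and 80%.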

Compound 4, a percentage reported as inhibition, at one concentration (the size of the read-out at that concentration, not a potency): 75.3%
Estimate against measurement, compound 4: 20.3 percentage points below; the measured number falls inside the stated range.
By their numbers in this assay, from the lowest: compound 1; then compound 2; then compounds 4 and 3 (each within the scatter of the next).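

Cyclohexyl in place of methyl on the ring nitrogen gives a number 9.1 percentage points lower from compound 3 to compound 4 (within the scatter) in this assay, so six heavy atoms in a non-aromatic ring sit there with no change beyond the scatter. Cyclohexyl also stands clear of both aryl groups, with a number 26.6 percentage points higher from compound 2 to compound 4 (beyond the scatter) and a number 58.1 percentage points higher from compound 1 to compound 4 (beyond the scatter), so a large group at this position does not by itself bring the low numbers of compound 1 and compound 2. Nothing available explains this difference. Still open, on these data alone, is how a benzyl group, a hydroxyethyl chain or an unsubstituted ring amine would behave on this nitrogen.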